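The source may report more compounds than this note shows. Statements on the series, on what has been measured and on what is new or still open speak of the compounds shown alone.

Working notes on the series, read in an ADME assay for permeability, using PAMPA; a lower number here means that the compound crosses the layer more slowly, a higher number that the compound crosses the layer faster. Compound 1 `O=C(Nc1ccc([N+](=O)[O-])cc1)c1cc(Cl)ccc1O` gives 127 10^-6 cm/s. Among the measured compounds shown here, compound 2 `O=C(Nc1ccc(Cl)cc1)c1cc(Cl)ccc1O` gives 297 10^-6 cm/s, the higher of the two numbers so far. For the measured compounds named here, the only measured step is a 2.3-fold higher number from compound 1 to compound 2 (0.37 log units; beyond the scatter), a modest one, with chloro in place of nitro on an aromatic carbon.

Next is compound 3 `Cc1ccc(NC(=O)c2cc(Cl)ccc2O)cc1`, which carries methyl in place of chloro on an aromatic carbon, para to a large group: methyl in place of chloro on an aromatic carbon. Going by the values given here, the measured step touches the same place on the ring, so it is the only guide, but it involves a different pair of groups and no measured compound carries methyl there. A step beyond the scatter in this assay is therefore not expected, and neither direction is favoured by much. The estimated step is a 1.1-fold lower number from compound 2 to compound 3 (0.06 log units; within the scatter). Compound 3 is expected at 260 10^-6 cm/s, with an estimated range of 130 10^-6 cm/s to 500 10^-6 cm/s.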

Compound 3, apparent permeability in the ADME assay: 21 10^-6 cm/s
Beside the measured number, compound 3's estimate is 12-fold (1.09 log units) above it; measured number outside the range, below it.
By their numbers in the ADME assay, from the lowest: compound 3; then compound 1; then compound 2.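

Among the compounds shown here, in the ADME assay the position para to a large group turns out to carry a large step, where the earlier compounds showed only a modest one: methyl in place of chloro gives a 14-fold lower number from compound 2 to compound 3 (1.15 log units; beyond the scatter). Methyl in place of nitro gives a 6.0-fold lower number from compound 1 to compound 3 (0.78 log units; beyond the scatter), so compound 3 stands lowest of the three, with its steps to both others beyond the scatter. Chloro and methyl each count one heavy atom, with no ring, no hydrogen-bond donor or acceptor and no net charge, so these counts do not separate compound 2 from compound 3, although the numbers do.

In a physicochemical assay for solubility (a higher number here means a more soluble compound, a lower number a less soluble compound), compound 2 gives < 1 ug/mL, which is a limit of the assay. In the physicochemical assay compound 3 gives < 1 ug/mL, which is also a limit of the assay. In the physicochemical assay the step between compound 2 and compound 3 cannot be read, both values being limits of the assay: the limit of < 1 ug/mL in the physicochemical assay, at which 2 of the 2 values shown sit. From the compounds shown here alone, whether the low permeability number is particular to methyl, or recurs with an ethyl group, a methoxy group or an amine at this position, stays open.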